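The source may report more compounds than this note shows. Statements on the series, on what has been measured and on what is new or still open speak of the compounds shown alone.

Compound 1 `CCN(CC)S(=O)(=O)c1ccc(S(=O)(=O)N2CCC[C@@H](C(=O)N[C@@H]3CCN(C(=O)OC(C)(C)C)C3)C2)cc1` gives 400 nM in a functional assay on BXPC-3 cells (Homo sapiens) for inhibition, read by MTT assay, with a stated time of 7 days; a lower number here means a stronger inhibitor, a higher number a weaker inhibitor. Compound 2 `CCN(CC)C(=O)[C@@H]1CCCN(S(=O)(=O)c2ccc(S(=O)(=O)N(CC)CC)cc2)C1` gives 10500 nM. Compound 3 `CCN1CC(NC(=O)[C@@H]2CCCN(S(=O)(=O)c3ccc(S(=O)(=O)N(CC)CC)cc3)C2)C1` gives > 30000 nM, which is a limit of the assay rather than a number.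

Compound 3 therefore stands as the weakest of the three, sitting at the limit of > 30000 nM in this assay, at which 1 of the 3 values shown sits. Compound 4 `CCN(CC)S(=O)(=O)c1ccc(S(=O)(=O)N2CCC[C@@H](C(=O)NC3COC3)C2)cc1` differs from it by oxetan-3-yl in place of 1-ethylazetidin-3-yl on an amide-type nitrogen. The steps that reach compound 3 are an at least 75-fold higher number from compound 1 to compound 3 (1.87 log units; beyond the scatter) and an at least 2.8-fold higher number from compound 2 to compound 3 (0.45 log units; beyond the scatter), both toward weaker inhibition. Going by the values given here, no measured step covers the oxetane change itself, and because compound 3 is only a limit the size of the step to compound 4 is open. Compound 4 is expected to give about 20000 nM, with a range of 4000 nM to 60000 nM. That estimate means an at least 1.5-fold lower number from compound 3 to compound 4 (0.17 log units; that floor lies within the scatter).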

Compound 4, half-maximal inhibitory concentration: 13800 nM
The estimate for compound 4 lay 1.4-fold (0.16 log units) above the measured number; the measured number falls inside the stated range.
By their numbers in this assay, from the lowest: compound 1; then compounds 2 and 4 (each within the scatter of the next). At a limit, above all of these: compound 3.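

In this assay, oxetan-3-yl on the amide-type nitrogen gives a readable number where 1-ethylazetidin-3-yl gave only a limit, with an at least 2.1-fold lower number from compound 3 to compound 4 (0.33 log units; beyond the scatter). Compound 3 remains a limit, so that step is only a floor: the limit of > 30000 nM in this assay, at which 1 of the 4 values shown sits. The oxetan-3-yl amide still stands level with the diethylamino amide, with a 1.3-fold higher number from compound 2 to compound 4 (0.12 log units; within the scatter), and far from the 1-(tert-butoxycarbonyl)pyrrolidin-3-yl amide, with a 35-fold higher number from compound 1 to compound 4 (1.54 log units; beyond the scatter).

The compounds shown leave open which part of the 1-(tert-butoxycarbonyl)pyrrolidin-3-yl group goes with its lower number. They also leave open how a pyrrolidin-3-yl group with a free amine would read on the same amide-type nitrogen.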